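A few compounds are considered here, and "the series" means these few. Any claim that something is new, unique, unknown or untested is made for them only; others in the source may bear on it.

Compound 1 `C(=C/c1[nH]cnc2ncnc1-2)\c1ccccc1`: 28%
Compound 2 `C(=C/c1ncnc2c1ncn2C1CCOCC1)\c1ccccc1`: 66%
Compound 3 `C(=C/c1ncnc2c1ncn2Cc1ccccc1)\c1ccccc1`: 93%

In a functional assay on K562 cells (Homo sapiens) for inhibition, read by thymidine incorporation, with a stated time of 48 h, tested at 10 ug/mL (a lower number here means less inhibition, a higher number more inhibition at the concentration tested (going by the name of the read-out)), compound 1 gives 28%, the lowest of the three numbers shown, with compound 2 beyond the scatter above it and compound 3 further still. For the measured compounds named here, the only single-place step measured is a number 27 percentage points higher from compound 2 to compound 3 (beyond the scatter), and it concerns the group on the aromatic nitrogen of the shared core. Compound 4 `COc1ccc(/C=C/c2[nH]cnc3ncnc2-3)cc1` is not yet measured; it differs from compound 1 by methoxy in place of hydrogen on an aromatic carbon. Going by the values given here, no measured step touches that place, so there is no direct guide. With nothing to point either way, compound 4 is expected to stay near compound 1, at an estimated 30% within 10% to 55%. The expected step of a number 2 percentage points higher from compound 1 to compound 4 (within the scatter) is estimated to lie within the usual scatter.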

Compound 4, a percentage reported as inhibition, at one concentration (the size of the read-out at that concentration, not a potency): 54%
Compound 4: the middle estimate sits 24 percentage points below what was measured; the range from low to high includes it.
By their numbers in this assay, from the lowest: compound 1; then compound 4; then compound 2; then compound 3.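

In this assay methoxy in place of hydrogen on an aromatic carbon, para to a large group, gives a number 26 percentage points higher from compound 1 to compound 4 (beyond the scatter) on the shared core. For the compounds shown here, this shows that the six-membered aromatic ring of carbon only, which no earlier step touched, is a place where a single change moves the read-out beyond the scatter. Nothing measured here explains the step. Still open, as far as these compounds go, is whether an amine or a carboxylic acid at this place would move the number the same way, and whether methoxy would do so on compound 3 as well.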